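Replacing 4-methylphenyl with 2-fluoro-6-methoxyphenyl: a half-life estimate

The compounds below may be only part of what the source reports. "The series", "measured", "known", "first", "only" and "open" are said of these compounds alone.

Measured half-lives:
Compound 1 `Cc1oc(-c2ccc(Cl)cc2)nc1CN1CCC(C(=O)NCCCN2C[C@H](C)C[C@H](C)C2)CC1`: > 0.5 h
Compound 2 `Cc1oc(-c2c(F)cccc2F)nc1CN1CCC(C(=O)NCCCN2C[C@H](C)C[C@H](C)C2)CC1`: 0.35 h
Compound 3 `Cc1ccc(-c2nc(CN3CCC(C(=O)NCCCN4C[C@H](C)C[C@H](C)C4)CC3)c(C)o2)cc1`: > 0.5 h

In an ADME assay on microsomes from liver (Rattus norvegicus) for metabolic stability, read by LC-MS, using NADPH, at 37 degrees C (a higher number here means that the compound lasts longer, a lower number that the compound disappears faster), compound 3 gives > 0.5 h, which is a limit and not a number. Compound 1 gives > 0.5 h, which is also a limit. Only compound 2 has a true number, 0.35 h. The values therefore cluster at the limit of > 0.5 h in this assay, at which 2 of the 3 values shown sit.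

The next structure is compound 4 `COc1cccc(F)c1-c1nc(CN2CCC(C(=O)NCCCN3C[C@H](C)C[C@H](C)C3)CC2)c(C)o1`. In it, 2-fluoro-6-methoxyphenyl stands in place of 4-methylphenyl on an aromatic carbon of the five-membered ring: 2-fluoro-6-methoxyphenyl in place of 4-methylphenyl on an aromatic carbon.

Going by the values given here, two measured steps bear on this change: an at least 1.4-fold lower number from compound 1 to compound 2 (0.15 log units; that floor lies within the scatter) and an at least 1.4-fold higher number from compound 2 to compound 3 (0.15 log units; that floor lies within the scatter). Both give only floors on their size, and those floors lie within the usual scatter. The third step, a step that the two limits leave unreadable from compound 1 to compound 3, cannot be sized at all. Among the compounds with values here, the closest guide is compound 2 at 0.35 h, the only measured compound whose group also carries fluorine. A modest drop in this assay is therefore expected, possibly no larger than the scatter, though one compound is a thin basis. The estimated step is an at least 1.4-fold lower number from compound 3 to compound 4 (0.15 log units; that floor lies within the scatter). For compound 4 the expected half-life is 0.35 h, with an estimated range of 0.15 h to 0.6 h.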

Compound 4, half-life: 0.143 h
The estimate for compound 4 lay 2.4-fold (0.39 log units) above the measured number; measured number below the stated range.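

In this assay, the group on this aromatic carbon of the five-membered ring can now be seen to move the half-life by more than the scatter: 2-fluoro-6-methoxyphenyl in place of 4-methylphenyl gives an at least 3.4-fold lower number from compound 3 to compound 4 (0.54 log units; beyond the scatter), and the same group in place of 4-chlorophenyl gives an at least 3.4-fold lower number from compound 1 to compound 4 (0.54 log units; beyond the scatter). Methoxy in place of fluoro on the phenyl ring gives a 2.4-fold lower number from compound 2 to compound 4 (0.39 log units; beyond the scatter), the only one of these steps with a true number at both ends, so two phenyl groups that both carry fluorine can differ clearly. The other two steps start from limits of the assay and not from numbers, so they give only floors, and the real drops may be larger: the limit of > 0.5 h in this assay, at which 2 of the 4 values shown sit.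

The compounds shown do not tell whether methoxy lowers the half-life on its own or only together with fluorine, and a phenyl ring carrying methoxy alone would address that. Going by these compounds, how an amine or a carboxylic acid on that phenyl ring would fare in this assay also remains open.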